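Swapping a para halogen for dimethylamino: cytotoxicity outlook

The compounds below may be only part of what the source reports. "The series", "measured", "known", "first", "only" and "open" are said of these compounds alone.

Three close analogues have been measured in an ADME assay on L6 cells (Rattus norvegicus) for cytotoxicity, read by resazurin assay, with a stated time of 72 h; on this read-out higher numbers stand for weaker inhibition and lower numbers for stronger inhibition. Compound 1 `O=C1[C@H]2N=NN(Cc3nc(-c4ccccc4)no3)[C@H]2C(=O)N1c1ccccc1` gives 47.3 ug/mL. Compound 2 `O=C1[C@H]2N=NN(Cc3nc(-c4ccc(Br)cc4)no3)[C@H]2C(=O)N1c1ccccc1`, which carries bromo in place of hydrogen on an aromatic carbon, gives 58.6 ug/mL. Compound 3 `O=C1[C@H]2N=NN(Cc3nc(-c4ccc(Cl)cc4)no3)[C@H]2C(=O)N1c1ccccc1`, with chloro at the same aromatic carbon, gives 49.5 ug/mL. The three numbers sit close together: a 1.2-fold higher number from compound 1 to compound 2 (0.09 log units; within the scatter), a 1.0-fold higher number from compound 1 to compound 3 (0.02 log units; within the scatter) and a 1.2-fold lower number from compound 2 to compound 3 (0.07 log units; within the scatter). On these numbers compound 3 stands second highest of the three, yet every gap to its neighbours lies within the scatter, so no order among them can be read.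

Compound 4 `CN(C)c1ccc(-c2noc(CN3N=N[C@@H]4C(=O)N(c5ccccc5)C(=O)[C@@H]43)n2)cc1` differs from compound 3 in one place: dimethylamino in place of chloro on an aromatic carbon. Among the measured compounds shown here, none of the measured steps involves a dimethylamino group; the steps that exist concern hydrogen, bromo and chloro at this aromatic carbon, and all of them were within the scatter. For the measured compounds named here, that is the only guide available, and it points to a shared core whose read-out in this assay has so far been insensitive to what sits at this position.

Compound 4 is therefore expected to land near compound 3, with a step of a 1.0-fold higher number from compound 3 to compound 4 (0.00 log units; within the scatter), and its estimated value is 50 ug/mL, within a range from 25 ug/mL to 100 ug/mL.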

Compound 4, half-maximal inhibitory concentration: > 100 ug/mL
Compound 4: no number, only a limit (the forecaster's own chance of this, stated with the estimate: 15%); at least 2.0-fold (0.30 log units) between middle value and limit.
By their numbers in this assay, from the lowest: compounds 1, 3 and 2 (each within the scatter of the next). At a limit, above all of these: compound 4.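

In this assay compound 4 stands at a limit and not at a number: the limit of > 100 ug/mL in this assay, at which 1 of the 4 values shown sits.

Even so, this aromatic carbon proves less indifferent than hydrogen, bromo and chloro suggested, since dimethylamino in place of hydrogen gives an at least 2.1-fold higher number from compound 1 to compound 4 (0.32 log units; beyond the scatter), the first step at this position that clears the scatter, in the direction of weaker inhibition of the cells. Against the two halogens the floors are smaller, an at least 2.0-fold higher number from compound 3 to compound 4 (0.30 log units; that floor lies within the scatter) and an at least 1.7-fold higher number from compound 2 to compound 4 (0.23 log units; that floor lies within the scatter), so on their own these two floors do not separate dimethylamino from chloro or bromo, although the real gaps could be wider.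

From the compounds shown here alone, how far the true value of compound 4 lies beyond its limit remains unknown. Among the compounds shown here, the one dimethylamino compound cannot say which feature of the group matters. Going by these compounds, it also stays open whether other groups at this aromatic carbon, such as a plain amine, a methoxy group or a carboxylic acid, would move the read-out in the same way.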